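The source may report more compounds than this note shows. Statements on the series, on what has been measured and on what is new or still open speak of the compounds shown alone.

Of the compounds shown here, three have been tested in a functional assay on the whole organism with Mus musculus as the target; a lower number here means that less compound is needed, a higher number that more compound is needed for the effect: compound 1 `CN1CCN(C(=O)/C=C/c2cccc(C(F)(F)F)c2)CC1`, compound 2 `CNC(=O)/C=C(\C)c1cccc(C(F)(F)F)c1` and compound 3 `CCN1C(=O)CCC1(O)c1cccc(C(F)(F)F)c1`. Compound 1 gives > 75 mg/kg, which is a limit of the assay and not a number. Compound 2 gives > 75 mg/kg, again a limit. Compound 3 gives > 75 mg/kg, also a limit. Together they show (the limit of > 75 mg/kg in this assay, at which 3 of the 3 values shown sit), so compound 3 cannot be ranked against the other two. Compound 4 `CCCCN1C(=O)CCC1(O)c1cccc(C(F)(F)F)c1` keeps the core of compound 3 and turns its ethyl into butyl: ethyl in place of hydrogen on a saturated chain carbon, two bonds along the chain from an amide-type nitrogen in a ring. Within the data shown here, no measured step shows what such a change does. The expected step is an at least 1.2-fold lower number from compound 3 to compound 4 (0.09 log units; that floor lies within the scatter), small and toward a lower dose, and it may not exceed the usual scatter. Compound 4 is estimated at 60 mg/kg, with a range of 25 mg/kg to 150 mg/kg.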

Compound 4, dose for half-maximal effect: 183 mg/kg
Compound 4: middle estimate off by 3.1-fold (0.48 log units), on the low side, and the stated range ends below it.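

In this assay compound 3 gives > 75 mg/kg, which is a limit and not a number, and the step from it to compound 4 cannot be read. On these data alone, whether going from ethyl to butyl changes the dose needed remains open.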